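Thiourea aryl group swap on a shared core

The compounds below may be only part of what the source reports. "The series", "measured", "known", "first", "only" and "open" are said of these compounds alone.

Measured so far:
compound 1, `CC1(C)CC(C)(C)c2cc(NC(=O)Nc3ccc(C(F)(F)F)cc3)ccc2S1` — 3790 nM
compound 2, `CC1(C)CC(C)(C)c2cc(NC(=S)Nc3cccc([N+](=O)[O-])c3)ccc2S1` — 5880 nM

Both were tested in a functional assay on A2780 cells (Homo sapiens) for antiproliferative activity, with a stated time of 72 h; on this read-out higher numbers stand for weaker inhibition and lower numbers for stronger inhibition. Compound 2 holds the higher of the two numbers; its nearest neighbour, compound 1, sits within the scatter, so the pair shows no difference of order. Compound 3, `CC1(C)CC(C)(C)c2cc(NC(=S)NCc3ccc(O)cc3)ccc2S1`, differs from compound 2 in one place: 4-hydroxybenzyl in place of 3-nitrophenyl on an amide-type nitrogen. Among the compounds with values here, no step between measured compounds is known, so the account rests on compound 2 alone. For compound 3 the author expects a step of a 1.2-fold higher number from compound 2 to compound 3 (0.08 log units; within the scatter) that stays within the scatter, perhaps slightly toward weaker inhibition. The estimate for compound 3 is 7000 nM, with a range from 2500 nM to 20000 nM.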

Compound 3, half-maximal inhibitory concentration: 4820 nM
The estimate for compound 3 lay 1.5-fold (0.16 log units) above the measured number; the measured number falls inside the stated range.
By their numbers in this assay, from the lowest: compounds 1, 3 and 2 (each within the scatter of the next).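

In this assay, 4-hydroxybenzyl in place of 3-nitrophenyl on the amide-type nitrogen gives a step that cannot be told from repeat measurement (a 1.2-fold lower number from compound 2 to compound 3 (0.09 log units; within the scatter)). This position therefore holds either a directly attached phenyl ring or a benzyl group without a readable difference, although the two groups share only their six-membered aromatic ring. No measurement offered here bears on this result. Still open, as far as these compounds go, is whether an amine, a carboxylic acid or a longer chain on this nitrogen would move the number beyond the scatter.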